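Nitrophenyl oxadiazole glycosides: acetyl to tosyl step

The compounds below may be only part of what the source reports. "The series", "measured", "known", "first", "only" and "open" are said of these compounds alone.

Three compounds of the series have numbers in a functional assay on A549 cells (Homo sapiens) for antiproliferative activity, read by sulforhodamine B assay, with a stated time of 48 h; on this read-out higher numbers stand for weaker inhibition of growth and lower numbers for stronger inhibition of growth. Compound 1 `COc1cc(C2=NOC(CO[C@@H]3O[C@H](CSc4ncn[nH]4)[C@H]4OC5(CCCC5)O[C@@H]34)C2)cc(OC)c1OC` gives 37000 nM in this assay. Compound 2 `CC1(C)O[C@H]2[C@H](OCc3noc(-c4ccc([N+](=O)[O-])cc4)n3)O[C@H](CO)[C@H]2O1` gives 99000 nM in this assay. Compound 3 `CC(=O)OC[C@H]1O[C@@H](OCc2noc(-c3ccc([N+](=O)[O-])cc3)n2)[C@@H]2OC3(CCCC3)O[C@@H]21` gives 29000 nM in this assay, the lowest of the three numbers; its gap to compound 1 lies within the usual scatter, while its gap to compound 2 lies beyond it. Going by the values given here, no pair among the measured compounds differs in only one place, so no single step has been computed.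

Compound 4 `Cc1ccc(S(=O)(=O)OC[C@H]2O[C@@H](OCc3noc(-c4ccc([N+](=O)[O-])cc4)n3)[C@@H]3OC4(CCCC4)O[C@@H]32)cc1` is not yet measured. It differs from compound 3 as follows: (4-methylphenyl)sulfonyl in place of acetyl on an oxygen on a saturated carbon. The shared core and the nitrophenyl oxadiazole of compound 3 are kept. Nothing in the measured set shows what such a replacement does in this assay, so the expected step is small, about the size of the scatter, and set towards a lower number, with a 1.9-fold lower number from compound 3 to compound 4 (0.29 log units; within the scatter) expected. For compound 4 the estimate in this assay is 15000 nM, with a range from 5000 nM to 60000 nM.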

Compound 4, concentration for 50% growth inhibition: > 100000 nM
Compound 4 gave a limit, no number; the forecaster's own chance of this, stated with the estimate: 15%; at least 6.6-fold (0.82 log units) between middle value and limit.
By their numbers in this assay, from the lowest: compounds 3 and 1 (each within the scatter of the next); then compound 2. At a limit, above all of these: compound 4.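

In this assay compound 4 gives > 100000 nM, which is a limit of the assay and not a number. Placing (4-methylphenyl)sulfonyl in place of acetyl on an oxygen on a saturated carbon brings an at least 3.4-fold higher number from compound 3 to compound 4 (0.53 log units; beyond the scatter), the first single change that can be read in the series, and it shows that growth inhibition depends on what this oxygen carries. The size of the step is only a lower bound, and its true size cannot be read: the limit of > 100000 nM in this assay, at which 1 of the 4 values shown sits.

The compounds shown do not separate the sulfonyl link from the aromatic ring, a question that methanesulfonyl or benzoyl on the same oxygen would address. Also open, going by these compounds, is whether an amine in place of this oxygen, or a longer acyl chain such as butanoyl on it, would give a lower number than acetyl.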